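The source may hold more compounds than are shown below. What is called first, only, known or untested is meant among the compounds shown, and "the series" means these compounds.

Compound 1, `CN1CCN(c2ccc(C3=NN(S(=O)(=O)c4ccc(Br)cc4)C(c4ccc(N(C)C)cc4)C3)cc2)CC1`, in a functional assay on MDA-MB-231 cells (Homo sapiens) for inhibition, read by sulforhodamine B assay, tested at 10 uM (on this read-out higher numbers stand for more inhibition at the one concentration tested (going by the name of the read-out) and lower numbers for less inhibition), gives 23.7%.
Compound 2, `CN(C)c1ccc(C2CC(c3ccc(-n4cncn4)cc3)=NN2C(=O)c2ccc(F)cc2)cc1`, in this assay gives 12.5%.
Compound 3, `CN(C)c1ccc(C2CC(c3ccc(-n4cncn4)cc3)=NN2S(C)(=O)=O)cc1`, in this assay gives 7.8%.

Among these three numbers compound 3 has the lowest; its nearest neighbour is compound 2, whose value lies within the scatter of it, while compound 1 stands beyond the scatter above it. Compound 4, `CN(C)c1ccc(C2CC(c3ccc(-n4cncn4)cc3)=NN2S(=O)(=O)c2ccc(Br)cc2)cc1`, has not yet been measured. It differs from compound 3 only at the sulfonyl sulfur: 4-bromophenyl in place of methyl on a sulfonyl sulfur.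

For the measured compounds named here, one measured step touches the same nitrogen: a number 4.7 percentage points lower from compound 2 to compound 3 (within the scatter). Compound 1 carries the same (4-bromophenyl)sulfonyl group as compound 4 but differs elsewhere, so its value can only be noted, not used as a step. With a single small step to go on, the change from methylsulfonyl to (4-bromophenyl)sulfonyl is expected to move this assay little, perhaps slightly upward. Compound 4 is therefore expected to give 13%, with a range from 2% to 28%, meaning an expected step of a number 5.2 percentage points higher from compound 3 to compound 4 (within the scatter).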

Compound 4, a percentage reported as inhibition, at one concentration (the size of the read-out at that concentration, not a potency): 10.4%
The estimate for compound 4 lay 2.6 percentage points above the measured number; the range from low to high includes it.
By their numbers in this assay, from the lowest: compounds 3, 4 and 2 (each within the scatter of the next); then compound 1.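

In this assay, 4-bromophenyl in place of methyl on a sulfonyl sulfur gives a number 2.6 percentage points higher from compound 3 to compound 4 (within the scatter), so a six-membered aromatic ring at this place does not separate the two sulfonyl groups on this read-out. The (4-bromophenyl)sulfonyl and (4-fluorophenyl)carbonyl groups on the ring nitrogen are not separated either, with a number 2.1 percentage points lower from compound 2 to compound 4 (within the scatter) as the printed step. For the compounds shown here, with (4-bromophenyl)sulfonyl held fixed, the change to 1H-1,2,4-triazol-1-yl from 4-methylpiperazin-1-yl on an aromatic carbon gives a number 13.3 percentage points lower from compound 1 to compound 4 (beyond the scatter) and is the only new step beyond the scatter.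

No measurement shown here offers an explanation for these numbers.

As far as these compounds go, it remains open whether an amine or a carboxylic acid on the sulfonyl sulfur would move this assay beyond the scatter. From the compounds shown here alone, it also remains open whether 4-methylpiperazin-1-yl would show the same difference with methylsulfonyl on the ring nitrogen.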